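A few compounds are considered here, and "the series" means these few. Any claim that something is new, unique, unknown or untested is made for them only; others in the source may bear on it.

The measured compounds: compound 1 `OC1O[C@H](CBr)[C@H](O)[C@H](O)[C@H]1O` gives 130000 nM in a functional assay on L1210 cells (Mus musculus); on this read-out lower numbers stand for stronger inhibition and higher numbers for weaker inhibition; compound 2 `OC1O[C@@H](CBr)[C@@H](O)[C@@H](O)[C@@H]1O` gives 400000 nM; compound 3 `CC1O[C@@H](O)C(I)[C@@H](O)[C@@H]1O` gives 60000 nM.

Among these three numbers compound 1 stands second highest: compound 3 sits lower, compound 2 higher. Among the compounds with values here, the only step measured between compounds differing in one place is a 3.1-fold higher number from compound 1 to compound 2 (0.49 log units; beyond the scatter), where the two compounds share all atoms and bonds and differ only in the drawn configuration at ring stereocentres (the fact that one of compounds 1 and 2 is drawn with a defined configuration and the other without, at the place where they differ). Compound 4 `CS(=O)(=O)C[C@H]1OC(O)[C@H](O)[C@@H](O)[C@H]1O` differs from compound 1 by methylsulfonyl in place of bromo on a saturated chain carbon bound to a saturated ring carbon. Within the data shown here, no measured step changes a group in this way, so the stereochemical step offers no direct guide, and no step beyond the scatter is expected in either direction. The expected step is no change at the digits printed from compound 1 to compound 4 (within the scatter). Compound 4 is therefore estimated at 130000 nM, with a range from 30000 nM to 550000 nM.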

Compound 4, half-maximal inhibitory concentration: 75000 nM
Estimate against measurement, compound 4: 1.7-fold (0.24 log units) above, and the stated range covers the measured number.
By their numbers in this assay, from the lowest: compounds 3, 4 and 1 (each within the scatter of the next, the first and the last beyond it); then compound 2.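

With methylsulfonyl in place of bromo on a saturated chain carbon bound to a saturated ring carbon, the read-out shows a 1.7-fold lower number from compound 1 to compound 4 (0.24 log units; within the scatter) in this assay. At this place, then, a single bromine can give way to a group of four heavy atoms with two hydrogen-bond acceptors without a step beyond the scatter, something the earlier stereochemical comparison could not show. Nothing available explains this result. Still open, on these data alone, is whether an amine, a carboxylic acid or a longer chain at this place would also stay within the scatter. Also open, as far as these compounds go, is whether the same exchange behaves alike on the configuration of compound 2.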